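The compounds below may be only part of what the source reports. "The series", "measured", "known", "first", "only" and "open" are said of these compounds alone.

Compound 1 `O=C1c2cc(C3CC3)nc(Oc3cccc(NS(=O)(=O)c4ccc(Cl)cc4)c3)c2C(=O)N1C1CC1`: 45 nM in a functional assay on HEK293 cells for agonist activity at Glucose-dependent insulinotropic receptor (Homo sapiens), read by cAMP accumulation, with a stated time of 30 min; a lower number here means that less compound is needed, a higher number that more compound is needed for the effect
Compound 2 `COc1cc2c(c(Oc3cccc(NS(=O)(=O)c4ccc(Cl)cc4)c3)n1)C(=O)N(C1CC1)C2=O`: 19 nM

Of the two measured compounds, compound 2 gives the lower number, the only shown step being a 2.4-fold lower number from compound 1 to compound 2 (0.37 log units; beyond the scatter). Compound 3 `Cc1cc2c(c(Oc3cccc(NS(=O)(=O)c4ccc(Cl)cc4)c3)n1)C(=O)N(C1CC1)C2=O` differs from compound 2 by methyl in place of methoxy on an aromatic carbon. Within the data shown here, no measured step exchanges methoxy for methyl; the one known step at this position, a cyclopropyl-to-methoxy change, was modest. A methyl group is therefore expected to give a number between those of compound 1 and compound 2, or one within the scatter of compound 2. For compound 3 the estimate is 30 nM, with a range of 12 nM to 80 nM, which is expected to mean a 1.6-fold higher number from compound 2 to compound 3 (0.20 log units; within the scatter).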

Compound 3, half-maximal effective concentration: 15 nM
Compound 3: the middle estimate sits 2.0-fold (0.30 log units) above what was measured, and the stated range covers the measured number.
By their numbers in this assay, from the lowest: compounds 3 and 2 (each within the scatter of the next); then compound 1.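

On the aromatic carbon next to the ring nitrogen, methyl in place of methoxy makes no clear difference in this assay (a 1.3-fold lower number from compound 2 to compound 3 (0.10 log units; within the scatter)). The methoxy oxygen, with its hydrogen-bond acceptor, can therefore go without a visible loss at this position. Cyclopropyl now stands apart from both smaller groups, since methyl in its place also lowers the number (a 3.0-fold lower number from compound 1 to compound 3 (0.48 log units; beyond the scatter)), just as methoxy did (a 2.4-fold lower number from compound 1 to compound 2 (0.37 log units; beyond the scatter)). As far as these compounds go, whether an amine, a chlorine atom or a longer chain at this carbon would keep the number this low stays open. No measurement shown gives a reason for these numbers.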